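A few compounds are considered here, and "the series" means these few. Any claim that something is new, unique, unknown or untested is made for them only; others in the source may bear on it.

Measured in an ADME assay on RAW264.7 cells (Mus musculus) for cytotoxicity, read by MTT assay, with a stated time of 24 h; on this read-out higher numbers stand for lower toxicity in this test and lower numbers for higher toxicity in this test:
- compound 1 `CC/C=C\C[C@H]1C(=O)C=C[C@H]1CC(=O)OCCC`: 35 uM
- compound 2 `CC/C=C\C[C@H]1C(=O)C=C[C@H]1CC(=O)OCc1ccccc1`: 31 uM

Going by the values given here, compound 2, at 31 uM, cannot be separated from compound 1, the only other compound measured here. The step between them is a 1.1-fold lower number from compound 1 to compound 2 (0.05 log units; within the scatter).

Compound 3 `CC/C=C\C[C@H]1C(=O)C=C[C@H]1CC(=O)Oc1ccc(O)cc1` has 4-hydroxyphenyl in place of benzyl on an oxygen next to a carbonyl group.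

Among the compounds with values here, only one measured step bears on this change, and it bears only loosely. That step also altered the group on this ester oxygen, and it amounted to no more than a 1.1-fold lower number from compound 1 to compound 2 (0.05 log units; within the scatter). As far as these compounds go, neither compound 1 nor compound 2 carries a hydroxyl group on its ring or has a ring bound directly to that oxygen, so the new features of compound 3 remain untested in this assay. The small size of that single step gives no ground for predicting a shift in either direction, so no change beyond the scatter is the working expectation, held with wide margins. The expected step is a 1.2-fold lower number from compound 2 to compound 3 (0.08 log units; within the scatter). The estimate for compound 3 is 26 uM, with an expected range of 10 uM to 65 uM.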

Compound 3, half-maximal toxic concentration: 49 uM
The estimate for compound 3 lay 1.9-fold (0.28 log units) below the measured number; low and high end bracket the measured number.
By their numbers in this assay, from the lowest: compounds 2, 1 and 3 (each within the scatter of the next).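

Compound 3 brings to the ester oxygen two features that neither earlier compound has in this assay: a ring bound directly to that oxygen and a hydroxyl group on the ring. Neither feature takes the read-out outside the usual scatter: 4-hydroxyphenyl in place of benzyl gives a 1.6-fold higher number from compound 2 to compound 3 (0.20 log units; within the scatter), and 4-hydroxyphenyl in place of propyl gives a 1.4-fold higher number from compound 1 to compound 3 (0.15 log units; within the scatter). Across these three compounds, then, propyl, benzyl and 4-hydroxyphenyl on this oxygen cannot be told apart in this test, so the tolerance seen with the first two groups now extends to a third, differently attached group. No accompanying measurement offers an explanation for these numbers.

The 4-hydroxyphenyl group introduces the direct ring attachment and the hydroxyl group together, so the contribution of each remains unresolved, and an unsubstituted phenyl group on the same oxygen would be needed to separate them. As far as these compounds go, it also remains open whether a group of another kind at this place, such as an amine, a carboxylic acid or a longer chain, would move the number beyond the scatter.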